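A few compounds are considered here, and "the series" means these few. Any claim that something is new, unique, unknown or untested is made for them only; others in the source may bear on it.

Measured compounds:
compound 1 `Cc1cc(N2CC[C@@H](C)[C@@H](N(C)c3ncnc4[nH]ccc34)C2)n2nc(SCC3CCCCC3)nc2n1`, 16300 nM 
compound 2 `Cc1cc(N2CC[C@@H](C)[C@@H](N(C)c3ncnc4[nH]ccc34)C2)n2nc(SCc3ccc(Br)cc3)nc2n1`, 28000 nM 

In a functional assay on BGC-823 cells (Homo sapiens) for inhibition, read by MTT assay, with a stated time of 72 h (on this read-out lower numbers stand for stronger inhibition and higher numbers for weaker inhibition), compound 1 stands at the lower of the two numbers, with compound 2 nearest to it. For the measured compounds named here, the one measured step, a 1.7-fold higher number from compound 1 to compound 2 (0.23 log units; within the scatter), shows that a 4-bromophenyl in place of cyclohexyl on a saturated chain carbon bound to a sulfur left the read-out within the scatter.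

Compound 3 `Cc1cc(N2CC[C@@H](C)[C@@H](N(C)c3ncnc4[nH]ccc34)C2)n2nc(SCCCc3ccccc3)nc2n1` differs from compound 1 by phenethyl in place of cyclohexyl on a saturated chain carbon bound to a sulfur. This change resembles the measured step, since again an aromatic six-membered carbon ring replaces the saturated one at the sulfur-bound chain, though here the chain is longer and carries no bromine. Because that step, a 1.7-fold higher number from compound 1 to compound 2 (0.23 log units; within the scatter), stayed within the scatter, no step beyond the scatter is expected in this assay from compound 1 to compound 3; the expected step is a 1.2-fold higher number from compound 1 to compound 3 (0.09 log units; within the scatter). Compound 3 is therefore estimated at 20000 nM, within a range from 8000 nM to 50000 nM.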

Compound 3, half-maximal inhibitory concentration: > 100000 nM
Compound 3 ended at the assay's limit; the forecaster's own chance of this, stated with the estimate: 10%; at least 5.0-fold (0.69 log units) between middle value and limit.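

In this assay, a change on a saturated chain carbon bound to a sulfur proved able to move the read-out beyond the scatter, which the earlier pair had not shown: phenethyl in place of cyclohexyl gave an at least 6.1-fold higher number from compound 1 to compound 3 (0.78 log units; beyond the scatter), and phenethyl in place of 4-bromophenyl gave an at least 3.5-fold higher number from compound 2 to compound 3 (0.55 log units; beyond the scatter). The value of compound 3 is a limit and not a number, so these steps give only a floor: the limit of > 100000 nM in this assay, at which 1 of the 3 values shown sits. Compound 2 and compound 3 both carry a six-membered aromatic ring of carbon only, so the presence of that ring alone does not settle the read-out at this place.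

The chain length and the bromine change together between compound 2 and compound 3, which leaves open which of them matters. The compounds shown also leave open how a benzyl without bromine, or an amine or a carboxylic acid on this chain, would read.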